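Triazolylamino in place of a lactam ring: solubility outlook

This account rests on a few compounds, and the source may have more. Where it says the series, first, only, none or still open, it means among the compounds named here.

Compound 1, `CC(C)NC(=O)CC(c1ccc(-c2ccc3cccc(F)c3c2)[nH]c1=O)C(C)C`, gives 24200 nM in a physicochemical assay for solubility, measured as kinetic solubility, at pH 2; on this read-out lower numbers stand for lower solubility and higher numbers for higher solubility.
Compound 2, `CC(C)C(/C=C1\CCNC1=O)c1ccc(-c2ccc3cccc(F)c3c2)[nH]c1=O`, gives 23600 nM in this assay.

Compound 2 holds the lowest of these two numbers, with compound 1 its nearest neighbour, but the step of a 1.0-fold lower number from compound 1 to compound 2 (0.01 log units; within the scatter) lies within the scatter, so the two compounds cannot be ranked against each other. Compound 3, `CC(C)C(Nc1nnc[nH]1)c1ccc(-c2ccc3cccc(F)c3c2)[nH]c1=O`, is the next compound in this series and differs from compound 2 at one place only: a group of 6 heavy atoms (2 carbon, 4 nitrogen; one five-membered aromatic ring with 3 hetero atoms) in place of a group of 7 heavy atoms (5 carbon, 1 nitrogen, 1 oxygen; one five-membered non-aromatic ring with 1 hetero atom), on a saturated chain carbon bound to an aromatic carbon and a saturated chain carbon.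

Within the data shown here, the only measured step, from compound 1 to compound 2, exchanged one group for another at the same place, and a 1.0-fold lower number from compound 1 to compound 2 (0.01 log units; within the scatter) showed no movement beyond the scatter. That step does not involve an aromatic ring with three hetero atoms, so it offers no direct guide to the new group; it only shows that this position has so far tolerated a change without shifting solubility. With no stronger evidence, compound 3 is expected to move by a 1.1-fold higher number from compound 2 to compound 3 (0.03 log units; within the scatter), that is, no step beyond the scatter, though with a wide range of uncertainty. Compound 3 is therefore estimated at 25000 nM, between 8000 nM and 80000 nM.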

Compound 3, solubility: 39000 nM
Beside the measured number, compound 3's estimate is 1.6-fold (0.19 log units) below it; the range from low to high includes it.
By their numbers in this assay, from the lowest: compounds 2, 1 and 3 (each within the scatter of the next).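

With (4H-1,2,4-triazol-3-yl)amino on this saturated chain carbon, this assay gives a 1.7-fold higher number from compound 2 to compound 3 (0.22 log units; within the scatter) and a 1.6-fold higher number from compound 1 to compound 3 (0.21 log units; within the scatter), so all three compounds now lie within the scatter of one another. The earlier pair compared only an open chain amide with a five-membered non-aromatic ring, whereas this result extends the comparison to a five-membered aromatic ring with 3 hetero atoms, and the entering group also has more hydrogen-bond donors and acceptors than the group it replaces. Even across these different groups, the readings at this position cannot be separated, and nothing available here offers an independent measurement that would explain them.

On these data alone, it remains open whether a carboxylic acid or a simple amine on this carbon would give a step beyond the scatter, which would show that the solubility reading at this position can respond to the group placed there. A phenylamino group would also be informative, as its all-carbon aromatic ring would test whether the nitrogen atoms of the triazole ring matter or whether any aromatic ring attached through an amino link gives a similar reading.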